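A ring swap on compound 2

This account rests on a few compounds, and the source may have more. Where it says the series, first, only, none or still open, it means among the compounds named here.

Of the compounds shown here, three sharing one core have been tested in a functional assay on HCT-116 cells (Homo sapiens) for cytotoxicity, read by MTT assay, with a stated time of 72 h; on this read-out lower numbers stand for stronger inhibition and higher numbers for weaker inhibition. Compound 2 `COc1ccc(/C=C/c2cc(C)no2)cc1OC` gives 87400 nM, the highest of the three numbers. Within the data shown here, removing one group gives compound 3 `COc1ccc(/C=C/c2cc(C)no2)cc1`, and this is the only measured step that links two compounds through a single change: a 3.9-fold lower number from compound 2 to compound 3 (0.59 log units; beyond the scatter), with hydrogen in place of methoxy on an aromatic carbon.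

The next step leads to compound 4 `COc1ccc(/C=C/c2cc(C)n[nH]2)cc1OC`, which has not been measured. It carries 3-methyl-1H-pyrazol-5-yl in place of 3-methyl-1,2-oxazol-5-yl on a double-bonded chain carbon bound to a double-bonded chain carbon. The methoxy step is a different change, so it shows only how far one edit can move the number in this small set.

Closer evidence comes from compound 1 `COc1ccc(/C=C/c2cc(C)n[nH]2)cc1`, which has the same pyrazolyl group and lacks the same methoxy as compound 3. Here compound 3 gives 22400 nM and compound 1, with the lower number, gives 9400 nM. This single pair suggests a modest move towards a lower number, so the expected step is a 2.4-fold lower number from compound 2 to compound 4 (0.39 log units; beyond the scatter). For compound 4 the estimate is 36000 nM, with an expected range from 13000 nM to 100000 nM.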

Compound 4, half-maximal inhibitory concentration: 51300 nM
The estimate for compound 4 lay 1.4-fold (0.15 log units) below the measured number; low and high end bracket the measured number.
By their numbers in this assay, from the lowest: compound 1; then compound 3; then compounds 4 and 2 (each within the scatter of the next).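

With the methoxy group in place, swapping 3-methyl-1,2-oxazol-5-yl for 3-methyl-1H-pyrazol-5-yl gives a 1.7-fold lower number from compound 2 to compound 4 (0.23 log units; within the scatter), so on this core the swap cannot be told apart from no change at all, even though one hydrogen-bond donor enters with the new ring. The pair without that methoxy offered only its printed values, compound 3 at 22400 nM and compound 1 at 9400 nM, and the new pair gives no clear sign of a matching shift. The methoxy change, by contrast, now holds up on a second core, with a 5.5-fold higher number from compound 1 to compound 4 (0.74 log units; beyond the scatter), and the two readings agree closely, making it the more dependable of the two edits in this small set: the same change on two cores in this assay, a 3.9-fold lower number (0.59 log units; beyond the scatter) from compound 2 to compound 3 and a 5.5-fold lower number (0.74 log units; beyond the scatter) from compound 4 to compound 1, 1.4-fold (0.15 log units) apart, within the scatter of two such steps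

Still open, from the compounds shown here alone, is what an amine or a hydroxyl would do in place of methoxy on an aromatic carbon, and whether a longer chain such as ethyl in place of the methyl on either ring would move the number. Going by these compounds, all four numbers come from this assay, so whether they would keep this order in other cells remains unknown.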